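Adding a butoxycarbonyl group to compound 3

The source may hold more compounds than are shown below. What is called first, only, known or untested is meant among the compounds shown, and "the series" means these compounds.

Compound 1, `CCOC(=O)c1ccc(-c2ccc(OCC)cc2)[nH]1`: in an assay on COS-7 cells for inhibition of patatin-like phospholipase domain-containing protein 2 (Mus musculus) (a higher number here means a weaker inhibitor, a lower number a stronger inhibitor), compound 1 gives > 200000 nM, which is a limit of the assay and not a number.
Compound 2, `CCNS(=O)(=O)c1cccc(-c2ccc(OCC)cc2)c1`: in this assay compound 2 gives 200000 nM.
Compound 3, `CCOc1ccc(-c2ccccc2)cc1`: in this assay compound 3 gives > 200000 nM, again a limit of the assay.

Compound 3 thus stands at the upper edge of what this assay can report, and the same holds for compound 1, so that two of the three values shown are limits (the limit of > 200000 nM in this assay, at which 2 of the 3 values shown sit). For the measured compounds named here, only one step between measured compounds is available: a number no lower from compound 2 to compound 3 (the limit leaves the size open), in which an ethylsulfamoyl group leaves an aromatic carbon and the number does not fall; its size cannot be read because compound 3 is a limit.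

Compound 4, `CCCCOC(=O)c1cccc(-c2ccc(OCC)cc2)c1`, differs from compound 3 by butoxycarbonyl in place of hydrogen on an aromatic carbon. The measured step bears on this change only as its mirror, a group entering an aromatic carbon, and it gives no readable size. Going by the values given here, nothing among the measured compounds points to a gain beyond the scatter, so no step beyond the scatter is expected, and the expected step is a number no higher from compound 3 to compound 4 (the limit leaves the size open). For compound 4 the estimated value is 200000 nM, expected to lie between 60000 nM and 400000 nM, with a real chance that only a limit is reported.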

Compound 4, half-maximal inhibitory concentration: 100000 nM
Estimate against measurement, compound 4: 2.0-fold (0.30 log units) above; the measured number falls inside the stated range.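

Placed on an aromatic carbon, meta to a group of 9 heavy atoms, butoxycarbonyl gives a number that can be read in this assay, and the change amounts to an at least 2.0-fold lower number from compound 3 to compound 4 (0.30 log units; that floor lies within the scatter). Exchanging ethylsulfamoyl for butoxycarbonyl gives a 2.0-fold lower number from compound 2 to compound 4 (0.30 log units; within the scatter), so these two groups cannot be told apart in this measurement. Steps that touch a limit cannot be read for their full size, and the set stays close to the edge of what is reported: the limit of > 200000 nM in this assay, at which 2 of the 4 values shown sit.

On these data alone, whether an amine, a carboxylic acid or the shorter ethoxycarbonyl group on this aromatic carbon would move the number beyond the scatter stays open. So does the effect of a longer chain in place of the ethoxy group shared by compound 3 and compound 4.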